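A few compounds are considered here, and "the series" means these few. Any claim that something is new, unique, unknown or untested is made for them only; others in the source may bear on it.

In a physicochemical assay for solubility (on this read-out lower numbers stand for lower solubility and higher numbers for higher solubility), compound 1 `COc1cc(/C=C(/SCc2ccc(Br)cc2)C(=O)c2ccc(C(=O)O)cc2)ccc1F` gives < 1000 ug/mL as a limit and not a number. Compound 2 `O=C(O)c1ccc(C(=O)/C(=C\c2cc([N+](=O)[O-])ccc2F)SCc2ccc(Br)cc2)cc1` gives < 1000 ug/mL which is also a limit. Compound 3 `O=C(O)c1ccc(C(=O)/C(=C\c2ccc([N+](=O)[O-])cc2F)SCc2ccc(Br)cc2)cc1` stands only at < 1000 ug/mL which is a limit as well. Compound 4 `O=C(O)c1ccc(C(=O)/C(=C\c2ccc(F)cc2[N+](=O)[O-])SCc2ccc(Br)cc2)cc1` differs from it thus: 4-fluoro-2-nitrophenyl in place of 2-fluoro-4-nitrophenyl on a double-bonded chain carbon bound to a double-bonded chain carbon and the two hold the same atoms, joined differently. The closest measured change is a step that the two limits leave unreadable from compound 2 to compound 3 and the others are a step that the two limits leave unreadable from compound 1 to compound 2 and a step that the two limits leave unreadable from compound 1 to compound 3 so none offers a size. All that can be read is the limit of < 1000 ug/mL in this assay, at which 3 of the 3 values shown sit, and no step beyond the scatter is expected in this assay in either direction. The estimated step is a step that the limit leaves unreadable from compound 3 to compound 4 and it carries no firm direction. Compound 4 is expected at 500 ug/mL with an estimated range from 100 ug/mL to 1000 ug/mL and probably as another limit.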

Compound 4, solubility: < 1000 ug/mL
Compound 4 gave a limit, no number (the forecaster's own chance of this, stated with the estimate: 90%); the middle value is on the limit's open side.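

In this assay, no step from compound 1, compound 2 or compound 3 to compound 4 can be read, as all four compounds give only a limit: the limit of < 1000 ug/mL in this assay, at which 4 of the 4 values shown sit.

The compounds shown leave open where any of the four truly stands and whether the change from 2-fluoro-4-nitrophenyl to 4-fluoro-2-nitrophenyl alters the read-out.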